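From morpholin-4-yl to pyrrolidin-1-yl on a sulfonyl sulfur

The source may report more compounds than this note shows. Statements on the series, on what has been measured and on what is new or still open speak of the compounds shown alone.

Measured in an ADME assay on HepG2 cells (Homo sapiens) for cytotoxicity, read by MTT assay, with a stated time of 48 h; a lower number here means a stronger inhibitor, a higher number a weaker inhibitor:
- Compound 1 `O=S(=O)(c1cccc(-c2ccc3ncnc(Nc4ccc(OCc5cccc(F)c5)c(Cl)c4)c3c2)c1)N1CCOCC1`: > 15000 nM
- Compound 2 `O=S(=O)(c1ccc(-c2ccc3ncnc(Nc4ccc(OCc5cccc(F)c5)c(Cl)c4)c3c2)cc1)N1CCCCC1`: > 15000 nM
- Compound 3 `O=S(=O)(c1ccc(-c2ccc3ncnc(Nc4ccc(OCc5cccc(F)c5)c(Cl)c4)c3c2)cc1)N1CCCC1`: > 15000 nM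

Compound 1 stands at a limit and has no exact number. The other two entries are limits as well: the limit of > 15000 nM in this assay, at which 3 of the 3 values shown sit.

Compound 4 `O=S(=O)(c1cccc(-c2ccc3ncnc(Nc4ccc(OCc5cccc(F)c5)c(Cl)c4)c3c2)c1)N1CCCC1` has not been measured. It differs from compound 1 as follows: pyrrolidin-1-yl in place of morpholin-4-yl on a sulfonyl sulfur.

The closest measured change also brings in pyrrolidin-1-yl on a sulfonyl sulfur, but there it replaces piperidin-1-yl: a step that the two limits leave unreadable from compound 2 to compound 3. It therefore gives neither a size nor a direction to carry over, and no step beyond the scatter is expected in this assay. The expected change is a step that the limit leaves unreadable from compound 1 to compound 4. Compound 4 is estimated at 20000 nM, with an expected range of 10000 nM to 40000 nM.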

Compound 4, half-maximal inhibitory concentration: > 15000 nM
Compound 4: no number, only a limit (the forecaster's own chance of this, stated with the estimate: 80%); the middle value does not contradict the limit.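

Compound 1 and compound 4 each give only a limit and no exact number in this assay, so no step can be read between them: the limit of > 15000 nM in this assay, at which 4 of the 4 values shown sit. Whether pyrrolidin-1-yl in place of morpholin-4-yl changes the read-out at all stays open, as does the exact value of every compound shown.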